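The source may hold more compounds than are shown below. What is called first, only, known or untested is meant among the compounds shown, and "the series" means these compounds.

- Compound 1 `COc1cc(C(=O)c2sc3ccccc3c2-c2ccc(C)cc2)cc(OC)c1OC`: 3700 nM
- Compound 2 `COc1cc(C(=O)c2sc3ccccc3c2Nc2ccc(C)cc2)cc(OC)c1OC`: 3500 nM
- Compound 3 `CCOc1ccc(Nc2c(C(=O)c3cc(OC)c(OC)c(OC)c3)sc3ccccc23)cc1`: 700 nM

These values come from a functional assay on HeLa cells (Homo sapiens) for antiproliferative activity, read by MTT assay, with a stated time of 72 h; on this read-out lower numbers stand for stronger inhibition and higher numbers for weaker inhibition. Compound 2 stands second highest of the three numbers, though its gap to its nearest neighbour is only a 1.1-fold lower number from compound 1 to compound 2 (0.02 log units; within the scatter). The other gap is larger, at a 5.0-fold lower number from compound 2 to compound 3 (0.70 log units; beyond the scatter).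

Compound 4 `COc1cc(C(=O)c2sc3cc(C)ccc3c2Nc2ccc(C)cc2)cc(OC)c1OC` is compound 2 with one change: methyl in place of hydrogen on an aromatic carbon. The new methyl replaces a hydrogen on an aromatic carbon of the shared core, part of a fused system of two rings.

Going by the values given here, no measured step alters the core, so the evidence here is only indirect. Putting ethoxy in place of methyl on an aromatic carbon elsewhere in the molecule gave a modest shift, a 5.0-fold lower number from compound 2 to compound 3 (0.70 log units; beyond the scatter). Replacing 4-methylphenyl with (4-methylphenyl)amino gave a 1.1-fold lower number from compound 1 to compound 2 (0.02 log units; within the scatter). Neither step points to a direction for the new methyl, so no step beyond the scatter is expected, and the range must stay wide.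

The estimated change is a 1.2-fold lower number from compound 2 to compound 4 (0.07 log units; within the scatter). The expected value for compound 4 is 3000 nM, with an estimated range of 800 nM to 10000 nM.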

Compound 4, half-maximal inhibitory concentration: 980 nM
For compound 4 the middle estimate is 3.1-fold (0.49 log units) above the measured one, and the stated range covers the measured number.
By their numbers in this assay, from the lowest: compounds 3 and 4 (each within the scatter of the next); then compounds 2 and 1 (each within the scatter of the next).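

In this assay, adding one methyl to the six-membered aromatic ring of the shared core gives a 3.6-fold lower number from compound 2 to compound 4 (0.55 log units; beyond the scatter), so this small change on a carbon of the fused system has a real effect on the read-out. The earlier steps shown here changed only the group attached outside the core, which makes this the first measured sign that the core itself can shift the number. Nothing measured here explains why adding this single carbon has this effect.

A methoxy group, a chlorine atom or a longer chain such as ethyl on the same carbon could behave like methyl or quite differently, and methyl on the other carbons of that ring remains an open case. Going by these compounds, it is also open whether this methyl and the ethoxy group of compound 3 would add together in one molecule.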